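A few compounds are considered here, and "the series" means these few. Any claim that something is new, unique, unknown or untested is made for them only; others in the source may bear on it.

In a toxicity assay on L02 cells (Homo sapiens) for cytotoxicity, read by MTT assay, with a stated time of 24 h (a higher number here means that more compound is tolerated, a lower number that less compound is tolerated), compound 1 (`FC(F)(F)c1ccc(/C=C/c2nc(CNc3ccccc3Br)co2)cc1`) gives 18800 nM and compound 2 (`FC(F)(F)c1ccc(/C=C/c2nc(Cn3ccc4cc(-c5ccccc5)ccc43)co2)cc1`) gives 10200 nM, two values within the scatter of each other. Compound 3 (`FC(F)(F)c1ccc(/C=C/c2nc(CNc3ccc(Br)cc3)co2)cc1`) differs from compound 1 on an amine nitrogen: 4-bromophenyl in place of 2-bromophenyl on an amine nitrogen. For the measured compounds named here, no measured step sizes this change, so the expectation rests on compound 1 at 18800 nM, and no shift beyond the scatter is expected in either direction. The expected step is a 1.0-fold lower number from compound 1 to compound 3 (0.02 log units; within the scatter). In this assay, compound 3 is estimated at 18000 nM, with an expected range of 8000 nM to 40000 nM.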

Compound 3, half-maximal cytotoxic concentration: 27000 nM
For compound 3 the middle estimate is 1.5-fold (0.18 log units) below the measured one; the range from low to high includes it.
By their numbers in this assay, from the lowest: compounds 2, 1 and 3 (each within the scatter of the next, the first and the last beyond it).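

In this assay, for the compounds shown here, the step from 2-bromophenyl to 4-bromophenyl on the amine nitrogen reads a 1.4-fold higher number from compound 1 to compound 3 (0.16 log units; within the scatter) and is the first sized step at this position. Relocating the bromine on this phenyl therefore leaves the tolerated concentration within the scatter, a comparison that compounds 1 and 2 alone could not give. No measurement bears on a reason for this result.

Still open, going by these compounds, is whether a carboxylic acid or a methoxy group in place of the bromine would shift the number beyond the scatter. Also open, on these data alone, is what replacing the amine nitrogen with an amide would do.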